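This account rests on a few compounds, and the source may have more. Where it says the series, first, only, none or still open, it means among the compounds named here.

Measured compounds in the series:
compound 1 `C/C=C(\C(=O)NCC(=O)O)C(NCc1ccc(NC(=O)CN)cc1)C(C)C`, in an assay on a protein complex (K562 cells) for inhibition of integrin alpha-5/beta-1 (Homo sapiens), with stated times of 30 min and 1 h (on this read-out higher numbers stand for weaker inhibition and lower numbers for stronger inhibition), compound 1 gives 170 nM
compound 2 `C/C=C(\C(=O)O)C(NCc1ccc(N)cc1)C(C)C`, compound 2 gives 9800 nM
compound 3 `C/C=C(\C(=O)O)C(C)NCc1ccc(N)cc1`, compound 3 gives 19 nM

Compound 2 stands at the highest number of the three, that is, the weakest inhibition in this assay. Among the compounds with values here, the step from compound 2 to compound 3 is the only one-place change measured so far: a 520-fold lower number from compound 2 to compound 3 (2.71 log units; beyond the scatter). That change sits on the saturated chain carbon and does not touch the carboxy group.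

Compound 4 `C/C=C(\C(=O)NCC(=O)O)C(NCc1ccc(N)cc1)C(C)C` is not yet measured. It differs from compound 2 by (carboxymethyl)amino in place of hydroxy on a carbonyl carbon. Within the data shown here, no measured step bears directly on this change. Compound 1 also carries the (carboxymethyl)carbamoyl group on the same carbonyl carbon, together with a further change at the aryl amine, and compound 1 gives 170 nM, whereas compound 2 gives 9800 nM; the two values differ by more than the scatter, but how much of that gap belongs to the (carboxymethyl)carbamoyl alone cannot be separated from these data.

On this basis compound 4 is expected to fall between compound 2 and compound 1, with an estimated 16-fold lower number from compound 2 to compound 4 (1.21 log units; beyond the scatter). The estimate for compound 4 in this assay is 600 nM, with a range from 120 nM to 3000 nM.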

Compound 4, half-maximal inhibitory concentration: 220 nM
Compound 4: the middle estimate sits 2.7-fold (0.44 log units) above what was measured, and the stated range covers the measured number.
By their numbers in this assay, from the lowest: compound 3; then compounds 1 and 4 (each within the scatter of the next); then compound 2.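

In this assay, the carbonyl carbon whose other neighbour is the double-bonded chain carbon is now a second place where one change moves the number beyond the scatter: (carboxymethyl)amino in place of hydroxy gives a 45-fold lower number from compound 2 to compound 4 (1.65 log units; beyond the scatter). The other new step, hydrogen in place of (aminomethyl)carbonyl on a nitrogen on an aromatic ring, gives a 1.3-fold higher number from compound 1 to compound 4 (0.11 log units; within the scatter), which lies within the scatter, so with the isopropyl-bearing core this substitution on the nitrogen shows no measurable effect, and the carboxy to (carboxymethyl)carbamoyl change alone accounts for the gap that compound 1 left unresolved. No independent measurement available here offers an explanation for the size of this step.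

The compounds shown do not tell whether the (carboxymethyl)amino change would have a similar effect on the core of compound 3, which carries methyl in place of isopropyl. They also leave open whether the terminal carboxylic acid of this group is required, or whether a methyl ester, a primary amide or a longer chain ending in a carboxylic acid would give a similar number.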